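This account rests on a few compounds, and the source may have more. Where it says the series, first, only, none or still open, it means among the compounds named here.

Measured so far in a functional assay on aorta (Rattus norvegicus, strain Sprague-Dawley) for inhibition; a higher number here means that more compound is needed for the effect, a lower number that less compound is needed: compound 1 `CCCOc1cc2c(c3c1C[C@@H]1[C@@H](C)CO[C@]1(C)O3)C[C@@H]1[C@@H](C)CO[C@]1(C)O2` gives 43000 nM; compound 2 `CC1COC2(C)Oc3cc(O)c4c(c3CC12)OC1(C)OCC(C)C1C4` gives 19000 nM.

Compound 1 holds the highest of the two numbers; compound 2 sits lower by a gap that lies beyond the usual scatter. Within the data shown here, the two differ in more than one place, so their pair gives no single-change step to lean on.

Compound 3 `CCCCCCOc1cc2c(c3c1C[C@@H]1[C@@H](C)CO[C@]1(C)O3)C[C@@H]1[C@@H](C)CO[C@]1(C)O2` is the next one to be measured. Its change from compound 1 is propyl in place of hydrogen on a saturated chain carbon, three bonds along the chain from an oxygen on an aromatic ring. Among the measured compounds shown here, no measured pair shows what the same difference does here. The expected step of a 1.2-fold lower number from compound 1 to compound 3 (0.09 log units; within the scatter) is small, most likely within the scatter, with no clear direction. Compound 3 is therefore estimated at 35000 nM, in a range from 12000 nM to 100000 nM.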

Compound 3, half-maximal effective concentration: > 200000 nM
Compound 3 was reported as a limit; the forecaster's own chance of this, stated with the estimate: 15%; middle value at least 5.7-fold (0.75 log units) from the limit.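

Propyl in place of hydrogen on a saturated chain carbon, three bonds along the chain from an oxygen on an aromatic ring, gives the series its first single-place step: an at least 4.6-fold higher number from compound 1 to compound 3 (0.66 log units; beyond the scatter). Going from propyl to hexyl at this position therefore raises the amount of compound needed for the effect, and the size of that rise has only a lower bound. The reading for compound 3 in this assay is a limit, not a number: the limit of > 200000 nM in this assay, at which 1 of the 3 values shown sits.

Going by these compounds, whether the rise grows steadily with chain length stays open, as one step gives no trend. Butyl, or a chain ending in an amine or a carboxylic acid, could show how this position responds.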